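The source may hold more compounds than are shown below. What is called first, only, known or untested is meant among the compounds shown, and "the series" means these compounds.

In a functional assay on P388 cells (Mus musculus) for cytotoxicity (on this read-out lower numbers stand for stronger inhibition and higher numbers for weaker inhibition), compound 3 (`Cc1cc(-c2c(F)cc3c(=O)c(Cc4ccccc4O)cn(C4CC4)c3c2F)cc(C)n1`) gives 670 nM, the middle of three numbers, with compound 1 (`Cc1cc(-c2c(F)cc3c(=O)c(Cc4c(O)cccc4O)cn(C4CC4)c3c2F)cc(C)n1`) at 250 nM and compound 2 (`COc1ccc(Cc2cn(C3CC3)c3c(F)c(-c4cc(C)nc(C)c4)c(F)cc3c2=O)cc1`) at 21000 nM. Compound 4 (`COc1ccccc1Cc1cn(C2CC2)c2c(F)c(-c3cc(C)nc(C)c3)c(F)cc2c1=O`) differs from compound 3 by methyl in place of hydrogen on an oxygen on an aromatic ring, so 2-hydroxyphenyl to 2-methoxyphenyl. Within the data shown here, no measured pair isolates this change. The nearest evidence is a 31-fold lower number from compound 2 to compound 3 (1.50 log units; beyond the scatter) and an 84-fold higher number from compound 1 to compound 2 (1.92 log units; beyond the scatter), both large, with the methoxy-bearing compound 2 on the high side. Against these stands a 2.7-fold higher number from compound 1 to compound 3 (0.43 log units; beyond the scatter), which is modest. A moderate step towards a higher number is therefore expected, smaller than those large steps. The estimated step is a 6.0-fold higher number from compound 3 to compound 4 (0.78 log units; beyond the scatter). Compound 4 is expected at 4000 nM, within an estimated range of 1200 nM to 15000 nM.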

Compound 4, half-maximal inhibitory concentration: 37000 nM
Compound 4: middle estimate off by 9.3-fold (0.97 log units), on the low side, and the stated range ends below it.
By their numbers in this assay, from the lowest: compound 1; then compound 3; then compounds 2 and 4 (each within the scatter of the next).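

In this assay, methyl in place of hydrogen on the oxygen now has a direct measurement, a 55-fold higher number from compound 3 to compound 4 (1.74 log units; beyond the scatter), a large step rather than the moderate one the indirect comparisons suggested. The position of the methoxy does not separate the two methoxy compounds, with 2-methoxyphenyl in place of 4-methoxyphenyl giving a 1.8-fold higher number from compound 2 to compound 4 (0.25 log units; within the scatter). Compared with the 2,6-dihydroxyphenyl group, 2-methoxyphenyl gives a 150-fold higher number from compound 1 to compound 4 (2.17 log units; beyond the scatter).

Nothing measured here explains the size of the methylation step. Going by these compounds, it remains open whether an amine or a carboxylic acid in place of the hydroxy would keep the number of compound 3 670 nM.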